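The source may hold more compounds than are shown below. What is called first, only, known or untested is meant among the compounds shown, and "the series" means these compounds.

Within the data shown here, compound 3 `COc1cc2ncnc(N3CCCc4ccccc43)c2cc1NC(=O)/C=C/CN1CCCC1` gives 1740 nM in a functional assay on PC-3 cells (Homo sapiens) for antiproliferative activity, read by MTT assay, with a stated time of 72 h (a lower number here means a stronger inhibitor, a higher number a weaker inhibitor), the second highest of the three numbers known so far; it sits close to compound 2 `O=C(/C=C/CN1CCCC1)Nc1cc2c(N3CCc4ccccc43)ncnc2cc1O[C@@H]1CCOC1`, which gives 1510 nM, and well apart from compound 1 `CC(C)=CC(=O)Nc1cc2c(N3CCCc4ccccc43)ncnc2cc1O[C@@H]1CCOC1`, which gives 9020 nM. Compound 4 `O=C(/C=C/CN1CCCC1)Nc1cc2c(N3CCCc4ccccc43)ncnc2cc1O[C@@H]1CCOC1` is compound 3 with oxolan-3-yl in place of methyl on an oxygen on an aromatic ring, so that a methoxy becomes an (oxolan-3-yl)oxy. No direct comparison of this exchange is available among the measured compounds, yet compound 2 already carries the (oxolan-3-yl)oxy group together with the same amide side chain and shows a number near that of compound 3. The step from compound 3 to compound 4 is therefore expected to stay within the scatter, at a 1.2-fold lower number from compound 3 to compound 4 (0.06 log units; within the scatter). Compound 4 is estimated at 1500 nM, within 600 nM to 4000 nM.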

Compound 4, half-maximal inhibitory concentration: 5780 nM
The estimate for compound 4 lay 3.9-fold (0.59 log units) below the measured number; the measured number lies above the stated range.
By their numbers in this assay, from the lowest: compounds 2 and 3 (each within the scatter of the next); then compounds 4 and 1 (each within the scatter of the next).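

In this assay, methoxy to (oxolan-3-yl)oxy on the oxygen on the aromatic ring is not a neutral exchange: it brings a 3.3-fold higher number from compound 3 to compound 4 (0.52 log units; beyond the scatter). With the (oxolan-3-yl)oxy group kept, 1,2,3,4-tetrahydroquinolin-1-yl in place of 2,3-dihydro-1H-indol-1-yl brings a 3.8-fold higher number from compound 2 to compound 4 (0.58 log units; beyond the scatter), while 3-(pyrrolidin-1-yl)prop-1-en-1-yl in place of 2-methylprop-1-en-1-yl on the carbonyl carbon brings only a 1.6-fold lower number from compound 1 to compound 4 (0.19 log units; within the scatter). Nothing available explains these steps. Still open, from the compounds shown here alone, is how an ethoxy or a 2-methoxyethoxy group on that oxygen would compare with methoxy and (oxolan-3-yl)oxy.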